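Dipeptide methyl esters on a bis(pyridylmethyl)amine head: cytotoxicity notes

The source may report more compounds than this note shows. Statements on the series, on what has been measured and on what is new or still open speak of the compounds shown alone.

compound 1 `COC(=O)[C@@H](C)NC(=O)[C@@H](C)NC(=O)CN(Cc1ccccn1)Cc1ccccn1`: 90000 nM
compound 2 `COC(=O)[C@@H](C)NC(=O)[C@@H](C)NC(=O)Cn1cc(CN(Cc2ccccn2)Cc2ccccn2)nn1`: 133000 nM

In an ADME assay on COLO357 cells (Homo sapiens) for cytotoxicity, read by MTT assay, with a stated time of 72 h (a higher number here means a weaker inhibitor, a lower number a stronger inhibitor), compound 1 gives 90000 nM and compound 2 gives 133000 nM. Compound 2 carries the highest of the two numbers, yet its gap to compound 1 lies within the scatter, so the two read alike. Compound 3 `COC(=O)CNC(=O)CNC(=O)Cn1cc(CN(Cc2ccccn2)Cc2ccccn2)nn1` differs from compound 2 by (((methoxycarbonyl)methyl)carbamoyl)methyl in place of 1-((1-(methoxycarbonyl)ethyl)carbamoyl)ethyl on an amide-type nitrogen. For the measured compounds named here, no step of this kind has been measured, and with two matching weak values in hand no shift beyond the scatter is expected in this assay, in either direction. Compound 3 is accordingly estimated at 130000 nM (range 60000 nM to 280000 nM), an expected step of a 1.0-fold lower number from compound 2 to compound 3 (0.01 log units; within the scatter).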

Compound 3, half-maximal inhibitory concentration: 137000 nM
For compound 3 the middle estimate is 1.1-fold (0.02 log units) below the measured one, and the stated range covers the measured number.
By their numbers in this assay, from the lowest: compounds 1, 2 and 3 (each within the scatter of the next).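

In this assay the change from 1-((1-(methoxycarbonyl)ethyl)carbamoyl)ethyl to (((methoxycarbonyl)methyl)carbamoyl)methyl on an amide-type nitrogen gives a 1.0-fold higher number from compound 2 to compound 3 (0.01 log units; within the scatter) and so shows that the defined stereocentres of the leaving group can be lost here without a shift beyond the scatter. No supporting measurement bears on this result.

From the compounds shown here alone, whether a carboxylic acid in place of the methyl ester, or a longer chain on this amide-type nitrogen, would move the number beyond the scatter remains open.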